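A few compounds are considered here, and "the series" means these few. Any claim that something is new, unique, unknown or untested is made for them only; others in the source may bear on it.

Three compounds that share one core, and differ only in the group carried by an oxygen on an aromatic ring, have been measured in a functional assay on PC-3 cells (Homo sapiens) for antiproliferative activity, read by WST assay, with a stated time of 3 days; a lower number here means a stronger inhibitor, a higher number a weaker inhibitor. Compound 1 `CCOc1c(-c2cc(OC)c(OC)c(OC)c2)oc2ccccc2c1=O` gives 900 nM, compound 2 `CCC(C)Oc1c(-c2cc(OC)c(OC)c(OC)c2)oc2ccccc2c1=O` gives 38600 nM, and compound 3 `CCN(CC)CCCCCOc1c(-c2cc(OC)c(OC)c(OC)c2)oc2ccccc2c1=O` gives 6600 nM. Compound 3 therefore holds the middle place of the three numbers, weaker than compound 1 and stronger than compound 2.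

The next compound, compound 4 `CCCCCN(CCCCC)CCCCCOc1c(-c2cc(OC)c(OC)c(OC)c2)oc2ccccc2c1=O`, keeps the chain of compound 3 and changes only the amino group: dipentylamino in place of diethylamino on a saturated chain carbon, five bonds along the chain from an oxygen on an aromatic ring. The measured steps show that the numbers respond to this side chain. The step of a 43-fold higher number from compound 1 to compound 2 (1.63 log units; beyond the scatter) is large, while a 7.3-fold higher number from compound 1 to compound 3 (0.87 log units; beyond the scatter) and a 5.8-fold lower number from compound 2 to compound 3 (0.77 log units; beyond the scatter) are modest. None of them swaps diethylamino for another amino group, so they suggest a size for the coming step but do not settle its direction. The closest hint is the drop in a 5.8-fold lower number from compound 2 to compound 3 (0.77 log units; beyond the scatter), though a 7.3-fold higher number from compound 1 to compound 3 (0.87 log units; beyond the scatter) runs the opposite way, so this lean is weak.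

A modest move to a lower number is expected, namely a 2.2-fold lower number from compound 3 to compound 4 (0.34 log units; beyond the scatter). For compound 4 the estimated value is 3000 nM, with an expected range of 900 nM to 12000 nM.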

Compound 4, half-maximal inhibitory concentration: 9600 nM
Estimate against measurement, compound 4: 3.2-fold (0.51 log units) below, and the stated range covers the measured number.
By their numbers in this assay, from the lowest: compound 1; then compounds 3 and 4 (each within the scatter of the next); then compound 2.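

In this assay, putting dipentylamino in place of diethylamino on a saturated chain carbon, five bonds along the chain from an oxygen on an aromatic ring, gives a 1.5-fold higher number from compound 3 to compound 4 (0.16 log units; within the scatter), so this pair cannot be told apart. The earlier compounds shown here showed that the group on the oxygen can move the number, but none of them changed the amino group at the far end of the chain; here, a group of 11 heavy atoms in place of one of 5 leaves the reading within the usual scatter, so at this place, this one change in chain size on the nitrogen has no measurable effect in this cell assay. No independent measurement is available to explain why these two amino groups read alike.

Still open, on these data alone, is whether this holds for an amino group of another shape at the same place, such as a ring amine like piperidine or morpholine, or for an unsubstituted primary amine. Also open, as far as these compounds go, is how a shorter chain between the oxygen and the diethylamino group would read.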